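Inverting the ring stereocentre: expected oral bioavailability

A few compounds are considered here, and "the series" means these few. Any claim that something is new, unique, unknown or untested is made for them only; others in the source may bear on it.

Compound 1 `CN(C)S(=O)(=O)N(C)[C@@H]1CCCn2c1nc(C(=O)NCc1ccc(F)cc1)c(O)c2=O` gives 42% in an in vivo ADME assay on the whole organism for pharmacokinetics, with Canis familiaris (Canis lupus familiaris) as the target, at a dose of 2 mg/kg by the oral route (a lower number here means that a smaller share of the oral dose reaches the circulation, a higher number that a larger share of the oral dose reaches the circulation), the lower of the two numbers in hand. Compound 2 `CN(C)C(=O)C(=O)N(C)[C@H]1CCCCn2c1nc(C(=O)NCc1ccc(F)cc1)c(O)c2=O` gives 61% in this assay, a value that lies beyond the scatter above compound 1. Compound 3 `CN(C)S(=O)(=O)N(C)[C@H]1CCCn2c1nc(C(=O)NCc1ccc(F)cc1)c(O)c2=O` differs from compound 1 only as follows: the two compounds have the same atoms and bonds and differ only in configuration as drawn: 1 of 1 stereo elements differ; a stereocentre at a saturated ring carbon is drawn R in compound 1 and S in compound 3. For the measured compounds named here, no step between two measured compounds of this kind is available, so nothing shows how the inverted configuration behaves here. For compound 3 the expected step is a number 3 percentage points higher from compound 1 to compound 3 (within the scatter), which is taken as no change beyond the scatter in either direction. Compound 3 is therefore estimated at 45% in this assay, within a range of 20% to 75%.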

Compound 3, oral bioavailability: 16%
Compound 3: the middle estimate sits 29 percentage points above what was measured; the whole stated range lies above it.
By their numbers in this assay, from the lowest: compound 3; then compound 1; then compound 2.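

In this assay the configuration at this saturated ring carbon matters on its own, with a number 26 percentage points lower from compound 1 to compound 3 (beyond the scatter), so the R form drawn in compound 1 is the better of the two. For the compounds shown here, this is the first step to isolate a stereocentre, and no change of group contributes to it. The step can be assigned to the inversion alone because of one fact: the fact that compounds 1 and 3 differ only in the configuration as drawn.

From the compounds shown here alone, it remains open whether inversion at this carbon has a similar effect when the side chain there carries an acetyl group or a morpholine amide. Going by these compounds, the pharmacokinetic process behind the step also remains unknown.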